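The compounds below may be only part of what the source reports. "The series", "measured", "known", "first", "only" and "open" are said of these compounds alone.

Measured so far in an ADME assay on the whole organism with Oryza sativa as the target, tested at 1 uM; on this read-out lower numbers stand for a stronger effect and higher numbers for a weaker effect at the one concentration tested:
- compound 1 `Cc1ccccc1NC(=O)N[C@@H](C)c1ccccc1`, which gives 99%
- compound 2 `C[C@H](NC(=O)Nc1ccccc1C(F)(F)F)c1ccccc1`, which gives 98%
- compound 3 `C[C@H](NC(=O)Nc1ccccc1F)c1ccccc1`, which gives 92%

Compound 3 holds the lowest of the three numbers, yet its distance to compound 2 and to compound 1 is within the scatter in each case, so the three read as alike. Compound 4 `C[C@H](NC(=O)Nc1ccccc1I)c1ccccc1` differs from compound 3 by iodo in place of fluoro on an aromatic carbon. Going by the values given here, the steps that bear on this are the three earlier swaps of a small group on the same aromatic carbon: a number 1 percentage points lower from compound 1 to compound 2 (within the scatter), a number 7 percentage points lower from compound 1 to compound 3 (within the scatter) and a number 6 percentage points lower from compound 2 to compound 3 (within the scatter), each within the scatter. The expected step is therefore a number 3 percentage points higher from compound 3 to compound 4 (within the scatter), no change beyond the scatter. Compound 4 is estimated at 95%, with a range from 85% to 100%.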

Compound 4, a percentage reported as activity, at one concentration (the size of the read-out at that concentration, not a potency): 100%
Estimate against measurement, compound 4: 5 percentage points below, and the stated range covers the measured number.
By their numbers in this assay, from the lowest: compounds 3, 2, 1 and 4 (each within the scatter of the next).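

In this assay, the iodo group gives a number 8 percentage points higher from compound 3 to compound 4 (within the scatter) and a number 2 percentage points higher from compound 2 to compound 4 (within the scatter) and a number 1 percentage points higher from compound 1 to compound 4 (within the scatter) with no step beyond the scatter. With iodo added, all four groups on this aromatic carbon, ortho to a large group, read as alike, so exchanging methyl, trifluoromethyl, fluoro and iodo here shows no clear effect on this read-out. No measurement is available that could explain this flat result.

As far as these compounds go, whether an amine or a carboxylic acid on this carbon would shift the number beyond the scatter remains open. The same question stands for a longer chain.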